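Compound 3 to compound 4: a plain phenyl on the carbonyl

The compounds below may be only part of what the source reports. "The series", "measured", "known", "first", "only" and "open" are said of these compounds alone.

compound 1 `COc1cc(-c2nn(-c3cccc(NC(=O)c4cccc(C(F)(F)F)c4)c3)cc2-c2ccncc2)ccc1Cl` gives a limit (> 50000 nM)
compound 2 `COc1cc(-c2nn(-c3cccc(NC(=O)Nc4cccc(C(F)(F)F)c4)c3)cc2-c2ccncc2)ccc1Cl` gives a number (3110 nM)
compound 3 `COc1cc(-c2nn(-c3cccc(NC(=O)c4ccc(Cl)c(C(F)(F)F)c4)c3)cc2-c2ccncc2)ccc1Cl` gives a limit (> 32500 nM)

In a functional assay on IGROV-1 cells (Homo sapiens) for inhibition, read by sulforhodamine B assay, with a stated time of 48 h (a lower number here means a stronger inhibitor of growth, a higher number a weaker inhibitor of growth), compound 3 has only a limit (> 32500 nM). Compound 1 also has only a limit (> 50000 nM). Compound 4 `COc1cc(-c2nn(-c3cccc(NC(=O)c4ccccc4)c3)cc2-c2ccncc2)ccc1Cl` has phenyl in place of 4-chloro-3-(trifluoromethyl)phenyl on a carbonyl carbon. The closest measured change, chloro in place of hydrogen, gives a step that the two limits leave unreadable from compound 1 to compound 3 as its step. The large steps (an at least 16-fold lower number from compound 1 to compound 2 (1.20 log units; beyond the scatter) and an at least 10-fold higher number from compound 2 to compound 3 (1.01 log units; beyond the scatter)) both involve the (3-(trifluoromethyl)phenyl)amino group, which compound 4 does not carry. No step beyond the scatter is therefore expected in this assay, and another limit is likely. The expected step is a step that the limit leaves unreadable from compound 3 to compound 4 as estimated. Compound 4 is estimated at 40000 nM with an expected range of 12000 nM to 100000 nM in this estimate.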

Compound 4, concentration for total growth inhibition: > 100000 nM
Compound 4 ended at the assay's limit; the forecaster's own chance of this, stated with the estimate: 75%; middle value at least 2.5-fold (0.39 log units) away from the limit.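

In this assay compound 4 gives > 100000 nM, which is a limit. With phenyl in place of (3-(trifluoromethyl)phenyl)amino on the carbonyl carbon, the result is an at least 32-fold higher number from compound 2 to compound 4 (1.50 log units; beyond the scatter), so the bare phenyl compound also falls on the weak side of compound 2. The steps to compound 4 from compound 1 and from compound 3 cannot be read, so these limits show no order among the three phenyl compounds.

What the compounds shown leave open is whether a plain phenylamino group on the carbonyl would hold the number of compound 2 without its trifluoromethyl. On these data alone, how a carboxylic acid or a morpholine on that phenyl would read is also open.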